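Removing one methoxy group from compound 1

The source may hold more compounds than are shown below. What is called first, only, known or untested is meant among the compounds shown, and "the series" means these compounds.

This account follows a small series of pyrazole-linked enones that share a common core and differ in the two aryl ends. Compound 1 `COc1cc(-c2cc(/C=C/C(=O)c3ccc(N)cc3)[nH]n2)cc(OC)c1OC` is measured in a functional assay on SN12C cells (Homo sapiens) for inhibition, read by sulforhodamine B assay, with a stated time of 48 h (on this read-out higher numbers stand for weaker inhibition of growth and lower numbers for stronger inhibition of growth), and gives 4520 nM. Compound 2 `COc1ccc(-c2cc(/C=C/C(=O)c3ccc(OC)c(OC)c3)[nH]n2)cc1` gives 3780 nM in this assay, which sits within the scatter of the value for compound 1, so the two cannot be ordered. Compound 3 `COc1cc(-c2cc(/C=C/C(=O)c3ccc(Cl)c(Cl)c3)[nH]n2)cc(OC)c1OC` is reported in this assay only as a limit, > 100000 nM (the limit of > 100000 nM in this assay, at which 1 of the 3 values shown sits). Within the data shown here, the one step that can be measured, an at least 22-fold higher number from compound 1 to compound 3 (1.34 log units; beyond the scatter), concerns the aryl group on the carbonyl carbon.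

Compound 4 `COc1ccc(-c2cc(/C=C/C(=O)c3ccc(N)cc3)[nH]n2)cc1OC` is not yet measured in this assay. It differs from compound 1 on the other aryl ring: hydrogen in place of methoxy on an aromatic carbon. Among the measured compounds shown here, no measured step touches this ring, so the large step from compound 1 to compound 3 does not speak to it, and the pair of compound 1 and compound 2, which differ in both rings, offers no single-point comparison. The value of compound 4 is therefore expected close to that of compound 1, a 1.1-fold higher number from compound 1 to compound 4 (0.04 log units; within the scatter), with no step beyond the scatter anticipated. Compound 4 is estimated at 5000 nM, between 1800 nM and 15000 nM.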

Compound 4, concentration for total growth inhibition: 13700 nM
Compound 4: middle estimate off by 2.7-fold (0.44 log units), on the low side, and the stated range covers the measured number.
By their numbers in this assay, from the lowest: compounds 2 and 1 (each within the scatter of the next); then compound 4. At a limit, above all of these: compound 3.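

In this assay, the ring carrying the methoxy groups now has a measured step of its own: hydrogen in place of methoxy, on an aromatic carbon ortho to a methoxy group and meta to a large group, gives a 3.0-fold higher number from compound 1 to compound 4 (0.48 log units; beyond the scatter) with the 4-aminophenyl end unchanged. Among these compounds, this position therefore bears on the read-out, which the earlier compounds could not show, as their only measured step concerned the aryl group on the carbonyl carbon. No measurement given here accounts for this change.

At this carbon the compounds shown compare only methoxy and hydrogen, so it stays open how a hydroxyl group, a fluorine atom or an ethoxy group would read. On these data alone, it is also open whether the same replacement would give a similar step with 3,4-dichlorophenyl on the carbonyl carbon.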